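The source may hold more compounds than are shown below. What is called first, only, known or untested is meant among the compounds shown, and "the series" means these compounds.

Series notes.
- Compound 1 `C[C@@H](NC(=O)Nc1cccc(F)c1)c1ccccc1`: 95%
- Compound 2 `C[C@@H](NC(=O)Nc1ccccc1Cl)c1ccccc1`: 103%
- Compound 3 `C[C@@H](NC(=O)Nc1cccc(Cl)c1)c1ccccc1`: 91%

In an ADME assay on the whole organism with Oryza sativa as the target, tested at 1 uM (on this read-out higher numbers stand for a weaker effect at the one concentration tested and lower numbers for a stronger effect), compound 3 gives the lowest of the three numbers; compound 1 stands within the scatter of it, while compound 2 sits beyond the scatter above it. Compound 4 `C[C@@H](NC(=O)Nc1cccc(Cl)c1Cl)c1ccccc1` differs from compound 3 by chloro in place of hydrogen on an aromatic carbon, the new group sitting ortho to a chloro group. Among the compounds with values here, the one measured step, a number 4 percentage points lower from compound 1 to compound 3 (within the scatter), exchanges a single aromatic substituent and stayed within the scatter; no measured step adds a second substituent to that ring, so the bearing is loose. No step beyond the scatter is therefore expected in this assay, and the range is kept wide for the thin basis. Compound 4 is estimated at 93%, between 78% and 108%. The expected step is a number 2 percentage points higher from compound 3 to compound 4 (within the scatter).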

Compound 4, a percentage reported as activity, at one concentration (the size of the read-out at that concentration, not a potency): 100%
Beside the measured number, compound 4's estimate is 7 percentage points below it, within the range that was stated.
By their numbers in this assay, from the lowest: compounds 3, 1, 4 and 2 (each within the scatter of the next, the first and the last beyond it).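

In this assay the step of a number 9 percentage points higher from compound 3 to compound 4 (within the scatter) and the step of a number 3 percentage points lower from compound 2 to compound 4 (within the scatter) both come from chloro in place of hydrogen, ortho to a chloro group. A second chloro group on this aromatic ring therefore gives no step beyond the scatter from either single-chloro compound. No supporting data bear on this result.

Still open, on these data alone, is whether a group other than a halogen at this position, such as methoxy, an amine or a carboxylic acid, would move the number beyond the scatter.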